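Tail flick series: a benzyloxycarbonyl side chain in place of methylsulfanyl

This account rests on a few compounds, and the source may have more. Where it says the series, first, only, none or still open, it means among the compounds named here.

Measured so far:
compound 1, `CSCC[C@H](NC(=O)CN(c1nc(Cl)nc2[nH]cnc12)C1CC1)C(=O)OCc1ccccc1`: 17.6%
compound 2, `NC(=O)CC[C@H](NC(=O)CN(c1ncnc2c1ncn2C1CCCCO1)C1CC1)C(=O)OCc1ccccc1`: 10.7%

Both numbers come from a functional assay on the whole organism (Tail, strain ICR) with Mus musculus as the target, in the tail flick test, with a stated time of 150 min, at a dose of 25 umol/kg by the oral route; a lower number here means a weaker effect, a higher number a stronger effect of the compound at the dose given. In this assay compound 1 gives 17.6% and compound 2 gives 10.7%; the gap between the two lies within the usual scatter of the method, so nothing on these numbers separates compound 1 from compound 2. Both read-outs are modest at the dose given. The two compounds differ in more than one place, so no single step can be read from them.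

Compound 3, `O=C(CN(c1nc(Cl)nc2[nH]cnc12)C1CC1)N[C@@H](CCC(=O)OCc1ccccc1)C(=O)OCc1ccccc1`, has not yet been run in this assay. It is reached from compound 1 by one change: benzyloxycarbonyl in place of methylsulfanyl on a saturated chain carbon, three bonds along the chain from an amide-type nitrogen and a carbonyl carbon. Among the measured compounds shown here, no measured pair shows this change, so its effect is open. With only two modest read-outs as a base, the expected read-out for compound 3 is near the present numbers and the expected step of a number 2.6 percentage points lower from compound 1 to compound 3 (within the scatter) is not beyond the scatter in either direction. Compound 3 is estimated at 15%, within a range of 3% to 35%.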

Compound 3, a percentage reported as activity, at one dose (the size of the read-out at that dose, not a potency): 44.5%
For compound 3 the middle estimate is 29.5 percentage points below the measured one, outside the stated range (above it).
By their numbers in this assay, from the lowest: compounds 2 and 1 (each within the scatter of the next); then compound 3.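

In this assay, benzyloxycarbonyl in place of methylsulfanyl on a saturated chain carbon, three bonds along the chain from an amide-type nitrogen and a carbonyl carbon, gives a number 26.9 percentage points higher from compound 1 to compound 3 (beyond the scatter). Among the compounds shown here, this is the first readable step, since compound 1 and compound 2 differ in more than one place, and it shows that the read-out at this dose responds to what stands at this position and that a group carrying a six-membered aromatic ring of carbon only is accepted there with a gain rather than a loss. For the compounds shown here, nothing measured so far accounts for this gain.

Going by these compounds alone, the single step does not separate the contribution of the aromatic ring from that of the ester carbonyl, so a carboxylic acid, a methyl ester or a longer chain with a phenyl group at the same place would each be informative. It also leaves open whether the gain carries over to the core of compound 2, and how the read-out at this one dose and time relates to potency or to the duration of the effect.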